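Moving the Bromine on the Phenyl Group of Compound 1

The source may hold more compounds than are shown below. What is called first, only, known or untested is meant among the compounds shown, and "the series" means these compounds.

Measured so far in a functional assay on KB3 cells (Homo sapiens) for antiproliferative activity, read by MTT assay, with a stated time of 96 h; on this read-out higher numbers stand for weaker inhibition and lower numbers for stronger inhibition:
- Compound 1 `C=C(C)[C@H]1CC(=O)C(C)=C2[C@@H](C(=O)OCC)O[C@@H](c3cccc(Br)c3)[C@@H]21`: 30000 nM
- Compound 2 `C=C(C)[C@H]1CC=C(C)[C@@]2(O)[C@@H]1[C@H](c1cccc3ccccc13)O[C@@H]2C(=O)OC`: 10000 nM
- Compound 3 `C=C(C)[C@H]1CC=C(C)[C@@]2(O)[C@@H]1[C@H](c1cccc(Cl)c1Cl)O[C@@H]2C(=O)OCC`: 5000 nM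

Compound 1 stands highest of the three, which makes it the weakest inhibitor here, and its gaps to compound 2 and compound 3 are both beyond the usual scatter. The next candidate is compound 4 `C=C(C)[C@H]1CC(=O)C(C)=C2[C@@H](C(=O)OCC)O[C@@H](c3ccccc3Br)[C@@H]21`, which has the same atoms as compound 1, joined differently: 2-bromophenyl in place of 3-bromophenyl on a saturated ring carbon. In short, it carries 2-bromophenyl in place of 3-bromophenyl on a saturated ring carbon, and the rest of the molecule is unchanged.

Going by the values given here, no measured pair shows a change of this kind alone. Compound 2 and compound 3 differ from compound 1 in more than one place, so they offer no direct guide. With so small a change, no step beyond the scatter is expected in this assay. The estimated change is a 1.5-fold lower number from compound 1 to compound 4 (0.18 log units; within the scatter). For compound 4 the expected value is 20000 nM, with an estimated range of 8000 nM to 50000 nM.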

Compound 4, half-maximal inhibitory concentration: 70000 nM
For compound 4 the middle estimate is 3.5-fold (0.54 log units) below the measured one; measured number outside the range, above it.
By their numbers in this assay, from the lowest: compounds 3 and 2 (each within the scatter of the next); then compound 1; then compound 4.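

In this assay, putting 2-bromophenyl in place of 3-bromophenyl on this saturated ring carbon gives a 2.3-fold higher number from compound 1 to compound 4 (0.37 log units; beyond the scatter), a modest step but one beyond the scatter. Going by these compounds alone, this is the first pair here that differs in one place only, and it shows that where the bromine sits on the phenyl ring changes the number even though no atom is gained or lost. Nothing measured here accounts for the step.

On these data alone, it remains open whether bromine itself matters, or whether a plain phenyl or a phenyl carrying an amine would give a similar number at this ring carbon. As far as these compounds go, it is also open whether the same step would appear with a carboxylic acid in place of the ethoxycarbonyl group.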